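Removing One Methyl on Two Related Cores

The source may report more compounds than this note shows. Statements on the series, on what has been measured and on what is new or still open speak of the compounds shown alone.

Three compounds have been measured in a functional assay on LS174T cells (Homo sapiens) for antiproliferative activity; a lower number here means a stronger inhibitor, a higher number a weaker inhibitor:

Compound 1, `CN(C)c1ccc(/C=C/c2c(Cl)cccc2Cl)cc1`: 214 nM
Compound 2, `CNc1ccc(/C=C/c2c(Cl)cccc2Cl)cc1`: 50.1 nM
Compound 3, `CN(C)c1ccc(/C=C/c2c(Cl)cccc2Cl)cn1`: 30.1 nM

Compound 1 and compound 2 differ in one place only, (hydrogen in place of methyl on a nitrogen on an aromatic ring). That single change gave a 4.3-fold lower number from compound 1 to compound 2 (0.63 log units; beyond the scatter). Compound 3 carries a different core; how its core differs from that of compound 1 is not broken down here. The value of compound 3 lies within the scatter of that of compound 2, so no order between those two can be read from these numbers, while compound 1 sits clearly higher than both.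

Compound 4, `CNc1ccc(/C=C/c2c(Cl)cccc2Cl)cn1`, has not yet been measured. It is related to compound 3 by hydrogen in place of methyl on a nitrogen on an aromatic ring, the same change, at the same place, that turned compound 1 into compound 2. If that change behaves alike on the second core, a step of similar size would be expected in this assay; the estimate here is a 3.0-fold lower number from compound 3 to compound 4 (0.48 log units; beyond the scatter), resting on the single comparison of compound 1 with compound 2, which gave a 4.3-fold lower number from compound 1 to compound 2 (0.63 log units; beyond the scatter). Going by the values given here, with only one earlier example, and on another core, the uncertainty is wide. For compound 4 the expected value is 10 nM, with a likely range from 3 nM to 35 nM.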

Compound 4, half-maximal inhibitory concentration: 19.6 nM
Compound 4: middle estimate off by 2.0-fold (0.29 log units), on the low side; the range from low to high includes it.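

In this assay going from dimethylamino to methylamino on the second core gave a 1.5-fold lower number from compound 3 to compound 4 (0.19 log units; within the scatter) and so no change that can be told apart from scatter. The same change therefore did not carry over at the same size, and the gap between the two steps is larger than repeated measurements would be expected to produce: the same change on two cores in this assay, a 4.3-fold lower number (0.63 log units; beyond the scatter) from compound 1 to compound 2 and a 1.5-fold lower number (0.19 log units; within the scatter) from compound 3 to compound 4, 2.8-fold (0.44 log units) apart, beyond the scatter of two such steps. This shows that, for these two pairs, the size of the step depends on the core that carries it, but two pairs cannot show which feature of the cores is responsible or predict the step on a further core.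

The compounds shown leave open how either core would respond if the nitrogen carried two hydrogens, as a primary amine, or a longer chain such as ethyl. A series of that kind could show whether the two cores continue to diverge as the group on the nitrogen changes.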